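The source may report more compounds than this note shows. Statements on the series, on what has been measured and on what is new or still open speak of the compounds shown alone.

Measured compounds:
compound 1 `CCCCCCCn1c(N2CCN(C)CC2)nc2ccccc21` — 150 nM
compound 2 `CCCCCCCCCCn1c(N2CCN(C)CC2)nc2ccccc21` — 4200 nM
compound 3 `CN1CCN(c2nc3ccccc3n2CCOCCO)CC1` — 42 nM

In a functional assay on ileum for inhibition of histamine H1 receptor (Cavia porcellus) (a higher number here means a weaker inhibitor, a lower number a stronger inhibitor), compound 3 stands lowest of the three numbers. Its nearest neighbour is compound 1, reached by a 3.6-fold lower number from compound 1 to compound 3 (0.55 log units; beyond the scatter); its furthest is compound 2, reached by a 100-fold lower number from compound 2 to compound 3 (2.00 log units; beyond the scatter). Compound 4 `COCCn1c(N2CCN(C)CC2)nc2ccccc21` differs from compound 3 by hydrogen in place of hydroxymethyl on a saturated chain carbon bound to an oxygen on a saturated carbon. The chain on the aromatic nitrogen is thereby shortened, and the hydroxymethyl, which carries the single hydrogen-bond donor of the group that leaves, is lost.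

Within the data shown here, two measured steps bear on this part of the structure. The step of a 28-fold higher number from compound 1 to compound 2 (1.45 log units; beyond the scatter) shows that lengthening the chain made the number larger; the step of a 3.6-fold lower number from compound 1 to compound 3 (0.55 log units; beyond the scatter) shows that a shorter chain bearing the hydroxy group made it smaller. Which of the two, chain length or the hydroxy group, carried the gain in compound 3 cannot be separated on these three compounds. For compound 4 a modest move is therefore expected, in this assay most likely toward a somewhat higher number, as a 1.9-fold higher number from compound 3 to compound 4 (0.28 log units; within the scatter). Compound 4 is estimated at 80 nM, within a range of 25 nM to 250 nM.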

Compound 4, half-maximal inhibitory concentration: 13 nM
Beside the measured number, compound 4's estimate is 6.2-fold (0.79 log units) above it; the measured number lies below the stated range.
By their numbers in this assay, from the lowest: compound 4; then compound 3; then compound 1; then compound 2.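

In this assay, the change gives a 3.2-fold lower number from compound 3 to compound 4 (0.51 log units; beyond the scatter), so the hydroxymethyl and the single hydrogen-bond donor that leaves with it are not required for a low number at this position, and the hydroxy group did not carry the gain seen in compound 3. Methoxy in place of pentyl gives a 12-fold lower number from compound 1 to compound 4 (1.06 log units; beyond the scatter) and methoxy in place of octyl gives a 320-fold lower number from compound 2 to compound 4 (2.51 log units; beyond the scatter), and across all four compounds the number rises as the chain on the aromatic nitrogen lengthens, with no compound going against this order. No evidence on why these numbers move is available here. From the compounds shown here alone, it remains open whether the chain oxygen or the shortness of the chain carries the low number, which a butyl chain on the aromatic nitrogen would help to separate. Going by these compounds, what an amine or a carboxylic acid at the chain end would do also stays open.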